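From methoxy to diethylamino on a shared core

The source may report more compounds than this note shows. Statements on the series, on what has been measured and on what is new or still open speak of the compounds shown alone.

Measured in a functional assay on SW480 cells (Homo sapiens) for antiproliferative activity, read by MTT assay, with a stated time of 48 h; on this read-out higher numbers stand for weaker inhibition and lower numbers for stronger inhibition:
compound 1 `COC/C1=C/C[C@](C)(CCC=C(C)C)/C=C/[C@@H](OC(=O)C=C(C)C)[C@](C)(OC)/C=C/C1=O` gives 14600 nM
compound 2 `COC/C1=C/C[C@](C)(CCC=C(C)C)/C=C/[C@@H](OC(=O)C=C(C)C)[C@](C)(O)/C=C/C1=O` gives 3850 nM
compound 3 `CC(=O)O[C@]1(C)/C=C/C(=O)/C(CO)=C\C[C@](C)(CCC=C(C)C)/C=C/[C@H]1OC(=O)C=C(C)C` gives 2010 nM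

In this assay, compound 2 at 3850 nM cannot be told apart from compound 3 at 2010 nM, as the two values lie within the usual scatter. Among the compounds with values here, compound 1 stands clearly apart from compound 2, and this is the only single-place step measured: a 3.8-fold lower number from compound 1 to compound 2 (0.58 log units; beyond the scatter), with hydrogen in place of methyl on an oxygen on a saturated carbon.

The next compound is compound 4 `CCN(CC)C/C1=C/C[C@](C)(CCC=C(C)C)/C=C/[C@@H](OC(=O)C=C(C)C)[C@](C)(O)/C=C/C1=O`, which carries diethylamino in place of methoxy on a saturated chain carbon bound to a double-bonded ring carbon. Within the data shown here, the one measured step concerns a different group, so it bears only loosely on this change, and no measured step shows what this swap does. No shift beyond the scatter is therefore expected, and the estimated step is a 1.1-fold lower number from compound 2 to compound 4 (0.04 log units; within the scatter). For compound 4 the expected value is 3500 nM, with an estimated range of 1200 nM to 11000 nM.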

Compound 4, half-maximal inhibitory concentration: 270 nM
For compound 4 the middle estimate is 13-fold (1.11 log units) above the measured one; the measured number lies below the stated range.
By their numbers in this assay, from the lowest: compound 4; then compounds 3 and 2 (each within the scatter of the next); then compound 1.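

In this assay, replacing methoxy with diethylamino on a saturated chain carbon bound to a double-bonded ring carbon gives a 14-fold lower number from compound 2 to compound 4 (1.15 log units; beyond the scatter). Within the data shown here, the earlier single-place step, a 3.8-fold lower number from compound 1 to compound 2 (0.58 log units; beyond the scatter), concerned a different group, so this is the first sign that the read-out responds to what this chain position carries. The change brings in nitrogen and raises the group from 2 heavy atoms to 5, and the larger group at this place goes with the lower number. No available evidence accounts for the size of this step.

The compounds shown leave open whether the step goes with the nitrogen or with the larger group as a whole. Dimethylamino, a piperidine ring or an all-carbon chain at this place would separate the two.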